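Anilide change carried onto the benzyl core

A few compounds are considered here, and "the series" means these few. Any claim that something is new, unique, unknown or untested is made for them only; others in the source may bear on it.

Measured compounds:
- compound 1 `O=C(CN1CCN(c2nnc(Cc3ccncc3)c3ccccc23)CC1)Nc1cccc(F)c1`; in a functional assay on HT-29 cells (Homo sapiens) for cytotoxicity, read by MTT assay, with a stated time of 72 h (a higher number here means a weaker inhibitor, a lower number a stronger inhibitor), compound 1 gives 6130 nM
- compound 2 `O=C(CN1CCN(c2nnc(Cc3ccncc3)c3ccccc23)CC1)Nc1ccc(F)c(Cl)c1`; in this assay compound 2 gives 880 nM
- compound 3 `O=C(CN1CCN(c2nnc(Cc3ccccc3)c3ccccc23)CC1)Nc1cccc(F)c1`; in this assay compound 3 gives 95000 nM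

Compound 1 and compound 2 share a core and differ only in the anilide part: 3-chloro-4-fluorophenyl in place of 3-fluorophenyl on an amide-type nitrogen. That change gives a 7.0-fold lower number from compound 1 to compound 2 (0.84 log units; beyond the scatter). Compound 3 differs from compound 1 in the core, where (phenyl in place of pyridin-4-yl on a saturated chain carbon bound to an aromatic carbon), and the step is a 15-fold higher number from compound 1 to compound 3 (1.19 log units; beyond the scatter); compound 3 has the highest number of the three measured compounds.

Compound 4 `O=C(CN1CCN(c2nnc(Cc3ccccc3)c3ccccc23)CC1)Nc1ccc(F)c(Cl)c1` has not been measured. It differs from compound 3 as 3-chloro-4-fluorophenyl in place of 3-fluorophenyl on an amide-type nitrogen, the same change at the same place as between compound 1 and compound 2, now on the core of compound 3.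

In this assay compound 4 is expected to show a 6.3-fold lower number from compound 3 to compound 4 (0.80 log units; beyond the scatter), a step of roughly the size seen before. For the measured compounds named here, this rests on the single measured instance of the change, a 7.0-fold lower number from compound 1 to compound 2 (0.84 log units; beyond the scatter), carried over to the other core; nothing in the data shows whether the benzyl core responds alike, so the range is kept wide. The estimate for compound 4 is 15000 nM, with a range from 4000 nM to 50000 nM.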

Compound 4, half-maximal inhibitory concentration: 13300 nM
Estimate against measurement, compound 4: 1.1-fold (0.05 log units) above, and the stated range covers the measured number.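

In this assay, 3-chloro-4-fluorophenyl in place of 3-fluorophenyl on the amide-type nitrogen gives a 7.1-fold lower number from compound 3 to compound 4 (0.85 log units; beyond the scatter), and the step keeps its size on both cores: the same change on two cores in this assay, a 7.0-fold lower number (0.84 log units; beyond the scatter) from compound 1 to compound 2 and a 7.1-fold lower number (0.85 log units; beyond the scatter) from compound 3 to compound 4, 1.0-fold (0.01 log units) apart, within the scatter of two such steps. Phenyl in place of pyridin-4-yl gives a 15-fold higher number from compound 2 to compound 4 (1.18 log units; beyond the scatter), and this step also keeps its size with either anilide: the same change on two cores in this assay, a 15-fold higher number (1.19 log units; beyond the scatter) from compound 1 to compound 3 and a 15-fold higher number (1.18 log units; beyond the scatter) from compound 2 to compound 4, 1.0-fold (0.01 log units) apart, within the scatter of two such steps. In these four compounds, the anilide change carries over from one core to the other without a measurable loss or gain, but this rests on a single pair of cores and a single pair of anilides, and it shows neither why the steps match nor that they would match on any other core.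

The compounds shown do not separate the contribution of the chlorine from that of the fluorine in the entering anilide. Going by these compounds, it also remains open whether the step would hold with a cyclohexyl group on the amide-type nitrogen, or with a longer chain carrying the phenyl or pyridin-4-yl.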